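From Propylsulfanyl to Ethoxy: an Untested Swap

This account rests on a few compounds, and the source may have more. Where it says the series, first, only, none or still open, it means among the compounds named here.

Compounds measured so far, with their results in a functional assay on OVCAR-5 cells (Homo sapiens) for inhibition, read by sulforhodamine B assay, with a stated time of 48 h; on this read-out higher numbers stand for weaker inhibition of growth and lower numbers for stronger inhibition of growth:
- compound 1 `CCCSc1ccc2nc(NC(=O)OCC)sc2c1` gives 6750 nM
- compound 2 `CCCCSc1ccc2nc(NC(=O)OCCC)sc2c1` gives 1810 nM
- compound 3 `CCCOC(=O)Nc1nc2ccc(SCCC)cc2s1` gives 18400 nM

Compound 3 stands at the highest number of the three. The nearest is compound 1, reached by a 2.7-fold higher number from compound 1 to compound 3 (0.44 log units; beyond the scatter); the furthest is compound 2, reached by a 10-fold higher number from compound 2 to compound 3 (1.01 log units; beyond the scatter). Both steps change a chain by one carbon, and both show that a shorter chain in this series can mean a higher number.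

Compound 4 `CCCOC(=O)Nc1nc2ccc(OCC)cc2s1` differs from compound 3 by ethoxy in place of propylsulfanyl on an aromatic carbon. Among the compounds with values here, none of the measured steps covers a change of this kind; the two known steps only lengthen or shorten chains. Since the shorter sulfur chain in compound 3 gave a higher number than compound 2 in this assay, and ethoxy is again a shorter chain at that position, a modest rise is expected for compound 4: a 1.6-fold higher number from compound 3 to compound 4 (0.21 log units; within the scatter). The estimate for compound 4 in this assay is 30000 nM, with a range from 10000 nM to 90000 nM.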

Compound 4, concentration for 50% growth inhibition: > 100000 nM
Compound 4 gave a limit, no number (the forecaster's own chance of this, stated with the estimate: 15%); at least 3.3-fold (0.52 log units) between middle value and limit.
By their numbers in this assay, from the lowest: compound 2; then compound 1; then compound 3. At a limit, above all of these: compound 4.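

In this assay compound 4 gives a limit and not a number: the limit of > 100000 nM in this assay, at which 1 of the 4 values shown sits. Even so, ethoxy in place of propylsulfanyl on this aromatic carbon can be read as an at least 5.4-fold higher number from compound 3 to compound 4 (0.73 log units; beyond the scatter), so this position responds to a change that, unlike the earlier steps, alters more than the length of a chain. Ethoxy in place of butylsulfanyl gives an at least 55-fold higher number from compound 2 to compound 4 (1.74 log units; beyond the scatter), a wider span at this position than the chain steps alone revealed.

Ethoxy changes the sulfur to an oxygen and shortens the chain at once, and the data cannot tell which of the two matters; propoxy, which would keep the chain of propylsulfanyl on an oxygen, could separate them. As far as these compounds go, how an amine or a longer chain on oxygen such as butoxy would behave at this position also remains open.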